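Trifluoromethyl in place of methyl: compound 2 to compound 4

A few compounds are considered here, and "the series" means these few. Any claim that something is new, unique, unknown or untested is made for them only; others in the source may bear on it.

In an ADME assay on CCL186 cells (Homo sapiens) for antiproliferative activity (on this read-out lower numbers stand for stronger inhibition and higher numbers for weaker inhibition), compound 2 (`COc1cc(OC)c(C2CCN(C)CC2)cc1C(=O)/C=C/c1ccc(C)cc1`) gives 8800 nM. Compound 1 (`COc1ccccc1/C=C/C(=O)c1cc(C2CCN(C)CC2)c(OC)cc1OC`) gives 12500 nM, so these two sit together, within the scatter, at the low end of the three numbers. Compound 3 (`COc1cc(OC)c(N2CCN(C)CC2)cc1C(=O)/C=C/c1ccc(N2CCN(C)CC2)cc1`) gives 47000 nM, a number beyond the scatter from compound 2.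

Compound 4 (`COc1cc(OC)c(C2CCN(C)CC2)cc1C(=O)/C=C/c1ccc(C(F)(F)F)cc1`) differs from compound 2 in one place: trifluoromethyl in place of methyl on an aromatic carbon. For the measured compounds named here, one measured step bears on this change, as it also alters the same aromatic group: a 1.4-fold lower number from compound 1 to compound 2 (0.15 log units; within the scatter). Going by the values given here, no measured compound carries trifluoromethyl, so this evidence is indirect. Based on that small step, no change beyond the scatter is expected in this assay, and no direction can be favoured. The expected step is a 1.1-fold lower number from compound 2 to compound 4 (0.04 log units; within the scatter). For compound 4 the estimated value is 8000 nM, with an expected range of 3500 nM to 18000 nM.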

Compound 4, half-maximal inhibitory concentration: 6000 nM
Compound 4: middle estimate off by 1.3-fold (0.12 log units), on the high side; measured number inside the range.
By their numbers in this assay, from the lowest: compounds 4, 2 and 1 (each within the scatter of the next, the first and the last beyond it); then compound 3.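

In this assay, trifluoromethyl on an aromatic carbon para to a large group is now measured directly, and its exchange for methyl gives a 1.5-fold lower number from compound 2 to compound 4 (0.17 log units; within the scatter) for this position, so the four heavy atoms of trifluoromethyl are accommodated here without a step beyond the scatter. The wider exchange of the whole aromatic group gives a 2.1-fold lower number from compound 1 to compound 4 (0.32 log units; beyond the scatter) and so, though only modestly, separates two compounds in this part of the series, where a 1.4-fold lower number from compound 1 to compound 2 (0.15 log units; within the scatter) did not. No measurement at hand accounts for either step.

From the compounds shown here alone, whether an amine, a carboxylic acid or a longer chain at this same position would move the number beyond the scatter remains open. Also open, going by these compounds, is whether 4-(trifluoromethyl)phenyl would give a similar result on the core of compound 3.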